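Quinolin-2-yl Ester in Place of Cyclopropylmethyl Ester

A few compounds are considered here, and "the series" means these few. Any claim that something is new, unique, unknown or untested is made for them only; others in the source may bear on it.

Measured compounds:
Compound 1 `CC1=C(C(=O)OCc2ccccc2)C(c2ccc(Cl)cc2Cl)NC(=O)N1CCCCC(=O)O` — in an ADME assay on MCF7 cells (Homo sapiens) for cytotoxicity, read by CellTiter-Glo, with a stated time of 24 h (on this read-out higher numbers stand for weaker inhibition of growth and lower numbers for stronger inhibition of growth), compound 1 gives > 100000 nM, a limit of the assay.
Compound 2 `CC1=C(C(=O)OCc2ccccc2)C(c2ccc(Cl)cc2Cl)NC(=O)N1CCCC(=O)OCC1CC1` — in this assay compound 2 gives > 100000 nM, again a limit.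
Compound 3 `C/C=C/COC(=O)CCCN1C(=O)NC(c2ccc(Cl)cc2Cl)C(C(=O)OCc2ccccc2)=C1C` — in this assay compound 3 gives > 100000 nM, also a limit.

Compound 2 therefore stands only at a limit, as do the other two values shown; none of them is a number. The step from compound 2 to compound 4 `CC1=C(C(=O)OCc2ccccc2)C(c2ccc(Cl)cc2Cl)NC(=O)N1CCCC(=O)OCc1ccc2ccccc2n1` is quinolin-2-yl in place of cyclopropyl on a saturated chain carbon bound to an oxygen next to a carbonyl group. The measured steps around it are a step that the two limits leave unreadable from compound 1 to compound 2, a step that the two limits leave unreadable from compound 1 to compound 3 and a step that the two limits leave unreadable from compound 2 to compound 3, none of them readable in size, because of the limit of > 100000 nM in this assay, at which 3 of the 3 values shown sit. For the measured compounds named here, with no step of known size to build on, nothing points to a change beyond the scatter. The expected step is a step that the limit leaves unreadable from compound 2 to compound 4. Compound 4 is thus estimated at 150000 nM, within 40000 nM to 500000 nM, most likely reported again only as a limit.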

Compound 4, concentration for 50% growth inhibition: > 100000 nM
Compound 4: no number, only a limit; the forecaster's own chance of this, stated with the estimate: 80%; the middle value does not contradict the limit.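

In this assay compound 4 gives > 100000 nM, again a limit and not a number. The steps to compound 4 from compound 2 and compound 3 therefore cannot be read: the limit of > 100000 nM in this assay, at which 4 of the 4 values shown sit. From the compounds shown here alone, whether quinolin-2-yl in place of cyclopropyl alters growth inhibition at all stays open.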